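This account rests on a few compounds, and the source may have more. Where it says the series, first, only, none or still open, it means among the compounds named here.

Of the compounds shown here, three have so far been tested in a functional assay on the whole organism for inhibition, with Rattus norvegicus as the target, at a dose of 30 mg/kg; on this read-out higher numbers stand for more inhibition at the one dose given (going by the name of the read-out) and lower numbers for less inhibition. Compound 1, with the structure `N#Cc1ccccc1-c1nc2cccnc2o1`, gives 61% in this assay, the highest of the three numbers. Compound 2, `FC(F)(F)c1cccc(-c2nc3cccnc3o2)c1`, gives 7% in this assay, and compound 3, `COc1ccc(C#N)c(-c2nc3ncccc3o2)c1`, gives 3% in this assay; both of these values lie below the value of compound 1 by more than the usual scatter of repeated measurements. No two of the measured compounds differ from each other in only one place, so none of these gaps can be tied to a single structural change.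

Compound 4, `Clc1ccccc1-c1nc2cccnc2o1`, has not yet been measured. It differs from compound 1 in one place: chloro in place of cyano on an aromatic carbon.

Among the compounds with values here, because compound 1 gives 61% in this assay while the other two compounds, carrying different groups or a different core, sit far lower, the single swap is expected to cost part of that inhibition rather than all of it. The expected step is a number 26 percentage points lower from compound 1 to compound 4 (beyond the scatter), a move downward that reaches beyond the scatter. Compound 4 is therefore estimated to give 35% in this assay, with a likely range from 10% to 62%.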

Compound 4, a percentage reported as inhibition, in the whole organism at one dose (the size of the read-out at that dose, not a potency): 50%
Compound 4: the middle estimate sits 15 percentage points below what was measured; measured number inside the range.
By their numbers in this assay, from the lowest: compounds 3 and 2 (each within the scatter of the next); then compound 4; then compound 1.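

Within the data shown here, this is the first comparison in which only one place changes: in this assay, chloro in place of cyano on an aromatic carbon, ortho to a group of 9 heavy atoms, gives a step that is a number 11 percentage points lower from compound 1 to compound 4 (beyond the scatter). The cyano group, with its triple bond, is therefore not essential for inhibition at this position, since compound 4, with a single chlorine atom there, still gives 50% in this assay, although the swap does cost some of the read-out. No measurement among the data shown gives a reason for this step.

As far as these compounds go, whether an amine, a carboxylic acid or a longer chain on the same aromatic carbon would keep the read-out close to that of compound 1 or lose most of it remains open. From the compounds shown here alone, the step also comes from a single dose in this assay, so how compound 1 and compound 4 would compare at other doses, or how chloro would behave on a different core, remains unknown.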